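Methyl replaces phenyl on the tetrazole of compound 3

The source may report more compounds than this note shows. Statements on the series, on what has been measured and on what is new or still open speak of the compounds shown alone.

Compound 3 `O=C(CSc1nnnn1-c1ccccc1)N/N=c1/scc(-c2ccccc2)n1-c1ccccc1` was tested in a functional assay on C6 cells (Rattus norvegicus) for cytotoxicity, read by MTT assay, with a stated time of 24 h, tested at 25 ug/mL (a higher number here means a weaker effect of the compound at the concentration tested, a lower number a stronger effect), where compound 3 gives 42.5%. Among the three measured compounds this places compound 3 at the low end of the numbers together with compound 2 `Cn1nnnc1SCC(=O)N/N=c1/scc(-c2ccc(C#N)cc2)n1-c1ccccc1`, which gives 43.9%; the two lie within the scatter of each other. Compound 1 `Cc1ccc(-c2cs/c(=N/NC(=O)CSc3nnnn3C)n2-c2ccccc2)cc1` gives 60.7%, and the gap from compound 3 up to compound 1 lies beyond the scatter.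

Compound 4 `Cn1nnnc1SCC(=O)N/N=c1/scc(-c2ccccc2)n1-c1ccccc1` differs from compound 3 by methyl in place of phenyl on an aromatic nitrogen. Among the measured compounds shown here, the one measured step, a number 16.8 percentage points lower from compound 1 to compound 2 (beyond the scatter), concerns a different place, a change of a substituent on an aromatic carbon rather than on an aromatic nitrogen, and so does not bear directly on the step now considered. For the measured compounds named here, no measured pair shows the exchange of phenyl for methyl on the aromatic nitrogen. Compound 4 carries the same methyl-tetrazole as compound 1 and compound 2, whose numbers span a range beyond the scatter, and the same unsubstituted phenyl as compound 3.

Going by the values given here, with no direct precedent, the step is expected to be small: a number 5.5 percentage points higher from compound 3 to compound 4 (within the scatter). Compound 4 is therefore estimated at 48%, within a range from 34% to 62%.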

Compound 4, a percentage reported as activity, at one concentration (the size of the read-out at that concentration, not a potency): 64.2%
For compound 4 the middle estimate is 16.2 percentage points below the measured one; measured number above the stated range.
By their numbers in this assay, from the lowest: compounds 3 and 2 (each within the scatter of the next); then compounds 1 and 4 (each within the scatter of the next).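

In this assay, among the compounds shown here, the change from 1-phenyl-1H-tetrazol-5-yl to 1-methyl-1H-tetrazol-5-yl gives a number 21.7 percentage points higher from compound 3 to compound 4 (beyond the scatter), the first sign that the group on this aromatic nitrogen matters to the read-out. With methyl on that nitrogen, the substituent on the aromatic carbon can now be read across three compounds: hydrogen and methyl do not separate, a number 3.5 percentage points higher from compound 1 to compound 4 (within the scatter), whereas removing cyano gives a number 20.3 percentage points higher from compound 2 to compound 4 (beyond the scatter), so the earlier drop with cyano is a difference from hydrogen as well as from methyl. Compound 3 and compound 2 thus reach their similar numbers through changes in two different places, and nothing shown explains why either change has this effect.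

The compounds shown leave open where a benzyl group or a butyl chain on this nitrogen would fall relative to methyl and phenyl, and whether phenyl there combined with a nitrile on the aromatic carbon would lower the number further. Since each compound is read at a single concentration, they also leave open how these differences would appear across a range of concentrations.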